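Sulfonamide Substituent Swaps in Plasma Acetylhydrolase Inhibition

The compounds below may be only part of what the source reports. "The series", "measured", "known", "first", "only" and "open" are said of these compounds alone.

Three compounds were measured in an assay for inhibition of platelet-activating factor acetylhydrolase (Rattus norvegicus), in plasma, with stated times of 30 min and 10 min, tested at 250 nM; a lower number here means less inhibition, a higher number more inhibition at the concentration tested (going by the name of the read-out):
Compound 1 `N#Cc1cc(NS(=O)(=O)c2ccc(N)cc2)ccc1Oc1ccc(Cl)c(C(F)(F)F)c1` gives 67%.
Compound 2 `N#Cc1cc(NS(=O)(=O)c2ccc(N3CCNCC3)cc2)ccc1Oc1ccc(Cl)c(C(F)(F)F)c1` gives 68%.
Compound 3 `N#Cc1cc(NS(=O)(=O)c2ccc(NC(=O)N3CCOCC3)cc2)ccc1Oc1ccc(Cl)c(C(F)(F)F)c1` gives 64%.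

Compound 3 has the lowest of the three numbers, yet the step of a number 3 percentage points lower from compound 1 to compound 3 (within the scatter) and the step of a number 4 percentage points lower from compound 2 to compound 3 (within the scatter) both sit within the scatter, so no order among the three can be read. Compound 4 `CC(=O)N(C)c1ccc(S(=O)(=O)Nc2ccc(Oc3ccc(Cl)c(C(F)(F)F)c3)c(C#N)c2)cc1` differs from compound 3 in one place: acetyl(methyl)amino in place of ((morpholin-4-yl)carbonyl)amino on an aromatic carbon. Going by the values given here, the steps that bear on this are a number 4 percentage points lower from compound 2 to compound 3 (within the scatter), which also exchanged the group on that aromatic carbon, and a number 3 percentage points lower from compound 1 to compound 3 (within the scatter), which altered the nitrogen bearing the group. Both were within the scatter, so no change beyond the scatter is expected; the estimated step is a number 1 percentage points lower from compound 3 to compound 4 (within the scatter). For compound 4 the expected value is 63%, with a range of 50% to 76%.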

Compound 4, a percentage reported as inhibition, at one concentration (the size of the read-out at that concentration, not a potency): 45%
Estimate against measurement, compound 4: 18 percentage points above, outside the stated range (below it).
By their numbers in this assay, from the lowest: compound 4; then compounds 3, 1 and 2 (each within the scatter of the next).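

The group on this aromatic carbon, para to a large group, does affect the result: with acetyl(methyl)amino, this assay gives a number 19 percentage points lower from compound 3 to compound 4 (beyond the scatter), a number 23 percentage points lower from compound 2 to compound 4 (beyond the scatter) and a number 22 percentage points lower from compound 1 to compound 4 (beyond the scatter). So the numbers with amino, piperazin-1-yl and ((morpholin-4-yl)carbonyl)amino, which lie within the scatter of one another, do not carry over to every group here. No measurement available here explains this drop.

The compounds shown leave open whether the methyl on the nitrogen or the acetyl accounts for it. Acetylamino, which keeps the hydrogen on that nitrogen, would separate the two.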